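A Chloro Added to the Fused Ring of Compound 2

The source may hold more compounds than are shown below. What is called first, only, known or untested is meant among the compounds shown, and "the series" means these compounds.

Compound 1 `NCc1ccccc1N1CCc2ccccc21` gives 14.1 mg/kg in a functional assay on the whole organism for inhibition, with Mus musculus as the target, in the writhing test, at a dose of 10 mg/kg by the subcutaneous route; on this read-out higher numbers stand for an effect only at larger amounts of compound and lower numbers for an effect already at smaller amounts.
Compound 2 `NCc1cccc(N2CCc3ccccc32)c1` gives 4.2 mg/kg in this assay.

Of these two numbers, compound 2 holds the lower one, and compound 1 stands at a number that is larger by a margin beyond the usual scatter of this assay. Compound 3 `NCc1cccc(N2CCc3cc(Cl)ccc32)c1` differs from compound 2 in a single place: chloro in place of hydrogen on an aromatic carbon. Within the data shown here, no pair of measured compounds shows an exchange of this kind, so nothing in the data shows how large a step such a change brings or in which direction it runs. The step expected in this assay is therefore a modest one, a 1.1-fold lower number from compound 2 to compound 3 (0.02 log units; within the scatter), which may well stay within the scatter in either direction. On that basis compound 3 is estimated to give about 4 mg/kg in this assay, with a range from 1.5 mg/kg to 11 mg/kg.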

Compound 3, dose for half-maximal effect: 4.2 mg/kg
Beside the measured number, compound 3's estimate is 1.1-fold (0.02 log units) below it, and the stated range covers the measured number.
By their numbers in this assay, from the lowest: compounds 2 and 3 (each within the scatter of the next); then compound 1.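

In this assay, chloro in place of hydrogen on an aromatic carbon of the fused system brings no change at the digits printed from compound 2 to compound 3 (within the scatter). Among these compounds, compounds 1 and 2 both carry only hydrogen on this ring, so this is the first reading of a substituent there, and it shows that this carbon can carry a chlorine atom with the number staying within the scatter of compound 2. Nothing at hand bears on why the number holds at this position.

On these data alone, it remains open whether a different group on the same carbon, such as fluoro, methoxy or a nitrile, would leave the number equally in place. Also open, as far as these compounds go, is whether chloro on another carbon of this ring, or at this carbon in the core of compound 1, would do the same.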